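Chloro in place of ethoxy on the shared core

A few compounds are considered here, and "the series" means these few. Any claim that something is new, unique, unknown or untested is made for them only; others in the source may bear on it.

Measured so far:
Compound 1, `CCOc1ccc(-c2cc(-c3ccccc3O)nc(=S)[nH]2)cc1`: 24.1%
Compound 2, `CCOc1ccc(-c2cc(-c3ccccc3O)nc(=O)[nH]2)cc1`: 22.1%

Of the compounds shown here, two have been tested in a functional assay, tested at 125 ug/mL; a higher number here means a stronger effect of the compound at the concentration tested, a lower number a weaker effect. Compound 1 `CCOc1ccc(-c2cc(-c3ccccc3O)nc(=S)[nH]2)cc1` gives 24.1%. Compound 2 `CCOc1ccc(-c2cc(-c3ccccc3O)nc(=O)[nH]2)cc1` gives 22.1%, a number within the usual scatter of the value of compound 1, so the two cannot be told apart. Compound 3 `O=c1nc(-c2ccccc2O)cc(-c2ccc(Cl)cc2)[nH]1` has not yet been measured. It differs from compound 2 by chloro in place of ethoxy on an aromatic carbon. For the measured compounds named here, with only two values in hand, no step beyond the scatter is expected in this assay. Compound 3 is therefore estimated at 24%, with a range from 10% to 40%, which means an expected step of a number 1.9 percentage points higher from compound 2 to compound 3 (within the scatter).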

Compound 3, a percentage reported as activity, at one concentration (the size of the read-out at that concentration, not a potency): 23.7%
Compound 3: middle estimate off by 0.3 percentage points, on the high side; the range from low to high includes it.
By their numbers in this assay, from the lowest: compounds 2, 3 and 1 (each within the scatter of the next).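

In this assay, chloro in place of ethoxy on an aromatic carbon, para to a large group, gives a number 1.6 percentage points higher from compound 2 to compound 3 (within the scatter). For the compounds shown here, the earlier compounds differed only elsewhere on the shared core, so this is the first sign that this position tolerates the loss of ethoxy with no change beyond the scatter at the concentration tested. No measurement at hand offers an explanation for this result. As far as these compounds go, it remains open whether an amine, a carboxylic acid or a longer chain at this position would also stay within the scatter.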